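The source may hold more compounds than are shown below. What is called first, only, known or untested is meant among the compounds shown, and "the series" means these compounds.

Compound 3 `C=CCn1c(=O)/c(=C\c2ccccc2Cl)[nH]c(=O)/c1=C\c1ccccc1OC` gives 9200 nM in a functional assay on NCI-H1975 cells (Homo sapiens) for cytotoxicity, read by CCK-8 assay, with a stated time of 72 h (a higher number here means a weaker inhibitor, a lower number a stronger inhibitor), and that is the lowest of the two numbers available: compound 2 `C=CCn1c(=O)/c(=C\c2cccc(F)c2)[nH]c(=O)/c1=C\c1ccccc1OC` gives 25600 nM, and the step of a 2.8-fold lower number from compound 2 to compound 3 (0.44 log units; beyond the scatter) lies beyond the scatter. Compound 1 `COc1ccccc1/C=c1/[nH]c(=O)/c(=C\c2cccc(Cl)c2Cl)[nH]c1=O`, which carries no allyl group on the core, is reported only as "not active" (no number reported), so it contributes no number.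

Compound 4 `C=CCn1c(=O)/c(=C\c2cccc(Cl)c2Cl)[nH]c(=O)/c1=C\c1ccccc1OC` differs from compound 3 by a single change: chloro in place of hydrogen on an aromatic carbon, that is, a chloro group added to the ring that already bears one, giving a 2,3-dichlorophenyl in place of the 2-chlorophenyl. Among the measured compounds shown here, none of the measured steps addresses this change directly. For the measured compounds named here, the only measured step, a 2.8-fold lower number from compound 2 to compound 3 (0.44 log units; beyond the scatter), exchanges one halogenated ring for another and says nothing about a second chloro on the same ring. Compound 1 carries the same 2,3-dichlorophenyl but on a differently substituted core, so its outcome cannot be set against compound 3 as a step.

Going by the values given here, with no step that bears on the change, the expectation for compound 4 in this assay is a step of a 1.0-fold higher number from compound 3 to compound 4 (0.01 log units; within the scatter), that is, no change beyond the scatter. The estimate for compound 4 is therefore 9500 nM, with a range from 3000 nM to 32000 nM.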

Compound 4, half-maximal inhibitory concentration: 4500 nM
Estimate against measurement, compound 4: 2.1-fold (0.32 log units) above, within the range that was stated.
By their numbers in this assay, from the lowest: compound 4; then compound 3; then compound 2.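

In this assay, among the compounds shown here, a chloro group on an aromatic carbon, ortho to a chloro group, turns 2-chlorophenyl into 2,3-dichlorophenyl and brings a 2.0-fold lower number from compound 3 to compound 4 (0.31 log units; beyond the scatter), which is the first measured sign that this place on the ring responds to a substituent, since the earlier step only exchanged one halogenated ring for another. The wider step, a 5.7-fold lower number from compound 2 to compound 4 (0.76 log units; beyond the scatter), leaves the 2,3-dichlorophenyl compound with the lowest number of the series, yet this ring alone does not ensure a number, as compound 1, which carries it on a core without the allyl group, gives "not active" (no number reported). No measurement shown here accounts for the effect of the added chloro group.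

The compounds shown leave open whether this place specifically needs a chloro group, since nothing here tells how a fluoro, a bromo, a methyl or a methoxy group would fare there. They also leave open whether the added chloro group would have the same effect with a longer chain in place of the allyl group, or with an amine on the ring that keeps its methoxy group.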